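A Bicyclic Carbon Group Replaces the Oxolane Ring

The source may report more compounds than this note shows. Statements on the series, on what has been measured and on what is new or still open speak of the compounds shown alone.

Of the compounds shown here, three that share one core have been tested in an assay on HEK293 cells for positive allosteric modulation of metabotropic glutamate receptor 5 (Homo sapiens), read by FLIPR; on this read-out lower numbers stand for an effect already at smaller amounts and higher numbers for an effect only at larger amounts of compound. Compound 1 `O=C(C1CCCO1)N1CC(c2nc(-c3cccc(Cl)c3)no2)C1` gives only a limit in this assay, > 10000 nM. Compound 2 `Cc1ccc(C(=O)N2CC(c3nc(-c4cccc(F)c4)no3)C2)cc1` gives 6800 nM in this assay. Compound 3 `Cc1cccc(-c2noc(C3CN(S(=O)(=O)c4ccc(F)cc4)C3)n2)c1` likewise returns only a limit, > 10000 nM. Compound 1 therefore sits at the edge of what this assay can report, a position it shares with compound 3, while compound 2 alone shows a measurable number; this is captured by the limit of > 10000 nM in this assay, at which 2 of the 3 values shown sit. No pair among these compounds differs in a single place, so no measured step is available to guide the next change.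

Compound 4 `O=C([C@@H]1CC2CCC1C2)N1CC(c2nc(-c3cccc(Cl)c3)no2)C1` differs from compound 1 in one place: a group of 7 heavy atoms (7 carbon; 2 five-membered non-aromatic rings of carbon only) in place of a group of 5 heavy atoms (4 carbon, 1 oxygen; one five-membered non-aromatic ring with 1 hetero atom), on a carbonyl carbon. Going by the values given here, with no measured step of this kind, the direction of the change remains open, and a modest shift in either direction would not be surprising. Compound 4 is expected to give about 5000 nM in this assay, in a range from 1000 nM to 20000 nM. The expected step is an at least 2.0-fold lower number from compound 1 to compound 4 (0.30 log units; that floor lies within the scatter). It is also expected that a limit rather than a number remains a real possibility for compound 4.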

Compound 4, half-maximal effective concentration: 98 nM
Estimate against measurement, compound 4: 51-fold (1.71 log units) above; the measured number lies below the stated range.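

On a carbonyl carbon whose other neighbour is the amide-type nitrogen in a ring, replacing oxolan-2-yl with the bicyclic carbon group gives an at least 100-fold lower number from compound 1 to compound 4 (2.00 log units; beyond the scatter) in this assay. This first measured step shows that a change at this one place, with the rest of the molecule untouched, can turn a compound without a measurable number into one with a clear number. The compounds shown now divide evenly between measured numbers and a limit: the limit of > 10000 nM in this assay, at which 2 of the 4 values shown sit.

This single step changes several things at once, including the ring count, the size of the group, the loss of the ring oxygen with its hydrogen-bond acceptor, and the defined stereocentre, and it cannot show which of them matters. As far as these compounds go, whether cyclopentyl or an open chain such as tert-butyl would serve as well remains open, as does the effect of the opposite stereocentre.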